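The compounds below may be only part of what the source reports. "The series", "measured", "known", "first", "only" and "open" are said of these compounds alone.

In a functional assay on HCT-116 cells (Homo sapiens) for antiproliferative activity, read by MTT assay, with a stated time of 48 h (on this read-out higher numbers stand for weaker inhibition and lower numbers for stronger inhibition), three close relatives of a shared core have been measured. Compound 1 `NS(=O)(=O)c1ccc(Nc2ncc(F)c(Nc3nc4ccccc4s3)n2)cc1` gives 3260 nM. Compound 2 `Cc1cnc(Nc2ccc(S(N)(=O)=O)cc2)nc1Nc1nc2ccccc2s1` gives 1660 nM, the lowest of the three numbers, though its gap to compound 1 is within the scatter and only its gap to compound 3 is beyond it. Compound 3 `Cc1ccc2nc(Nc3nc(Nc4ccc(S(N)(=O)=O)cc4)ncc3C)sc2c1` gives 3870 nM. The step of a 2.0-fold lower number from compound 1 to compound 2 (0.29 log units; within the scatter) came with a methyl in place of fluoro on an aromatic carbon, and the step of a 2.3-fold higher number from compound 2 to compound 3 (0.37 log units; beyond the scatter) with a methyl in place of hydrogen on an aromatic carbon; both were small.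

Compound 4 `COc1ccc(Nc2ncc(C)c(Nc3nc4ccccc4s3)n2)cc1` has not yet been measured in this assay. It differs from compound 2 in one place: methoxy in place of sulfamoyl on an aromatic carbon. Neither measured step touches that part of the molecule, so no shown step points in a direction for this change, and the expectation rests on compound 2 alone, with a wide range. Compound 4 is expected to give 2500 nM, between 700 nM and 9000 nM. That estimate means a step of a 1.5-fold higher number from compound 2 to compound 4 (0.18 log units; within the scatter), expected to stay within the scatter.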

Compound 4, half-maximal inhibitory concentration: > 50000 nM
Compound 4 was reported as a limit (the forecaster's own chance of this, stated with the estimate: 5%); middle value at least 20-fold (1.30 log units) from the limit.
By their numbers in this assay, from the lowest: compounds 2, 1 and 3 (each within the scatter of the next, the first and the last beyond it). At a limit, above all of these: compound 4.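

In this assay, among these compounds, methoxy in place of sulfamoyl brings an at least 30-fold higher number from compound 2 to compound 4 (1.47 log units; beyond the scatter), whereas the earlier steps, made elsewhere on the molecule, were small. Compound 4 is given only as a limit and not as a number: the limit of > 50000 nM in this assay, at which 1 of the 4 values shown sits. Among the compounds shown, this place on the six-membered aromatic ring of carbon only is therefore where a single change moves the number most, and the true size of that step remains unknown.

The compounds shown cannot separate the loss of sulfamoyl from the arrival of methoxy, since both happen in the same step. Also open, going by these compounds, is whether an amine or a carboxylic acid on this carbon would keep the number close to that of compound 2, 1660 nM.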